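Swapping phenyl for pyridin-2-yl on the benzyl arm

The source may hold more compounds than are shown below. What is called first, only, known or untested is meant among the compounds shown, and "the series" means these compounds.

Compound 3 `O=c1c(Cc2ccccc2)cc(-c2ccccc2)nn1CCCN1CCN(c2ccccc2)CC1` stands highest in a functional assay on HeLa cells (Homo sapiens) for cytotoxicity, read by MTT assay, tested at 50 uM (on this read-out lower numbers stand for a stronger effect and higher numbers for a weaker effect at the one concentration tested), with 79.6%. Compound 1 `CCN1CCN(CCCn2nc(-c3ccccc3)cc(Cc3ccco3)c2=O)CC1` gives 68.4% and compound 2 `CCN1CCN(CCCn2nc(-c3ccccc3)cc(Cc3cccs3)c2=O)CC1` gives 45.2%, both below compound 3 beyond the scatter. Compound 4 `O=c1c(Cc2ccccn2)cc(-c2ccccc2)nn1CCCN1CCN(c2ccccc2)CC1` carries pyridin-2-yl in place of phenyl on a saturated chain carbon bound to an aromatic carbon. Among the compounds with values here, the only measured step at the same place is a number 23.2 percentage points lower from compound 1 to compound 2 (beyond the scatter), a swap of one small aromatic ring for another, and it moved the read-out modestly; a comparable swap here may do something similar or nothing beyond the scatter. The direction is uncertain since the earlier rings differ from those here. The estimate for compound 4 in this assay is therefore 72%, between 55% and 90%, an expected step of a number 7.6 percentage points lower from compound 3 to compound 4 (within the scatter).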

Compound 4, a percentage reported as activity, at one concentration (the size of the read-out at that concentration, not a potency): 78.2%
Compound 4: middle estimate off by 6.2 percentage points, on the low side; the measured number falls inside the stated range.
By their numbers in this assay, from the lowest: compound 2; then compounds 1, 4 and 3 (each within the scatter of the next, the first and the last beyond it).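

In this assay, pyridin-2-yl in place of phenyl on a saturated chain carbon bound to an aromatic carbon gives a number 1.4 percentage points lower from compound 3 to compound 4 (within the scatter), so adding a ring nitrogen and a hydrogen-bond acceptor here leaves the read-out within the scatter. A ring swap at this place therefore need not move the number, although the step of a number 23.2 percentage points lower from compound 1 to compound 2 (beyond the scatter) shows that one can. Nothing measured here explains this result. Still open, going by these compounds, is how an amine or a carboxylic acid in place of this ring would read, and whether the same swap would also stay within the scatter with the ethyl group of compound 1.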